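The source may report more compounds than this note shows. Statements on the series, on what has been measured and on what is new or still open speak of the compounds shown alone.

Measured compounds and their values:
- compound 1 `C#CCNC(=O)/C(C)=C(\C)c1ccc(C)cc1` — 150 mg/kg
- compound 2 `C=CCNC(=O)/C(C)=C(\C)c1ccc(C)cc1` — 150 mg/kg

The two measured compounds share the same core and differ only in the chain on the amide nitrogen. Within the data shown here, in a toxicity assay on the whole organism (strain Icem-CET (SPF Caw)) for cytotoxicity, with Mus musculus as the target (on this read-out higher numbers stand for an effect only at larger amounts of compound and lower numbers for an effect already at smaller amounts), compound 1 stands level with compound 2 at the digits given; the single measured step, no change at the digits printed from compound 1 to compound 2 (within the scatter), lies within the usual scatter of this read-out. Among the measured compounds shown here, that step concerns a vinyl in place of an ethynyl on a saturated chain carbon bound to an amide-type nitrogen, and it is the only comparison available.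

Compound 3 `C#CCNC(=O)/C(C)=C(\C)c1ccc(F)cc1` has not been measured. It differs from compound 1 by fluoro in place of methyl on an aromatic carbon. For the measured compounds named here, no measured step touches the aromatic ring, so nothing in the data speaks directly to this change; the one step that exists, which left the value unchanged, sits on the chain rather than the ring. With no evidence of a direction, compound 3 is expected to give 150 mg/kg in this assay, with a range from 75 mg/kg to 300 mg/kg. The expected step of no change at the digits printed from compound 1 to compound 3 (within the scatter) is estimated as no change beyond the scatter.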

Compound 3, dose for half-maximal effect: 100 mg/kg
Estimate against measurement, compound 3: 1.5-fold (0.18 log units) above; the measured number falls inside the stated range.
By their numbers in this assay, from the lowest: compounds 3, 1 and 2 (each within the scatter of the next).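

In this assay, the aromatic carbon para to a large group now has a measured step of its own, which the earlier pair could not give, as that pair differed only in the chain on the amide nitrogen. Fluoro in place of methyl at this position gives a 1.5-fold lower number from compound 1 to compound 3 (0.18 log units; within the scatter), so the exchange does not separate the two compounds beyond the usual scatter, and this ring position joins the chain as a place where one exchange has left the read-out within that scatter. Nothing else measured alongside this result bears on it or offers a way to interpret it.

The compounds shown leave open whether a different group on this aromatic carbon, such as trifluoromethyl, methoxy, an amine or a carboxylic acid, would move the number beyond the scatter, since methyl and fluoro are the only groups seen there. They also leave open whether fluoro would read the same alongside the vinyl-bearing chain of compound 2, and whether a longer chain on the amide nitrogen would change the value at all.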